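Swapping chloro for cyano in compound 3

The source may hold more compounds than are shown below. What is called first, only, known or untested is meant among the compounds shown, and "the series" means these compounds.

Values in a functional assay on SMMC-7721 cells (Homo sapiens) for cytotoxicity, read by MTT assay, with a stated time of 24 h; on this read-out lower numbers stand for stronger inhibition and higher numbers for weaker inhibition:
Compound 1 `N#Cc1ccc(S(=O)(=O)N2C/C(=C\c3cccnc3)C(=O)/C(=C/c3ccccc3C(F)(F)F)C2)cc1`: 9650 nM
Compound 2 `O=C1/C(=C/c2ccncc2)CNC/C1=C\c1ccccc1C(F)(F)F`: 4500 nM
Compound 3 `O=C1/C(=C/c2ccncc2)CN(S(=O)(=O)c2ccc(Cl)cc2)C/C1=C\c1ccccc1C(F)(F)F`: 5510 nM

On these numbers, compound 3 lies within the scatter of both compound 2 and compound 1, so its value gives no clear separation from either. Compound 4 `N#Cc1ccc(S(=O)(=O)N2C/C(=C\c3ccncc3)C(=O)/C(=C/c3ccccc3C(F)(F)F)C2)cc1` has not yet been measured. It differs from compound 3 by a single change, (cyano in place of chloro on an aromatic carbon), which is cyano in place of chloro on an aromatic carbon, para to a large group.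

Within the data shown here, no measured step makes this exchange directly. The nearest evidence is a 1.2-fold higher number from compound 2 to compound 3 (0.09 log units; within the scatter), a step that adds the (4-chlorophenyl)sulfonyl group to the amine nitrogen and stays within the scatter. Compound 1 already carries the (4-cyanophenyl)sulfonyl group of compound 4 but differs elsewhere in its structure, and compound 1 gives 9650 nM. Neither observation points to a large move, so no change beyond the scatter is expected in this assay, with only a slight lean towards the number of compound 1. The estimated change is a 1.2-fold higher number from compound 3 to compound 4 (0.07 log units; within the scatter). For compound 4 the expected value is 6500 nM, with an estimated range from 3500 nM to 12000 nM.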

Compound 4, half-maximal inhibitory concentration: 9610 nM
Compound 4: middle estimate off by 1.5-fold (0.17 log units), on the low side, and the stated range covers the measured number.
By their numbers in this assay, from the lowest: compounds 2, 3, 4 and 1 (each within the scatter of the next, the first and the last beyond it).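

In this assay the exchange of chloro for cyano, on an aromatic carbon para to a large group, is now read directly as a 1.7-fold higher number from compound 3 to compound 4 (0.24 log units; within the scatter) and so gives no separation between the two sulfonyl groups on its own. Measured against the free ring nitrogen, however, the (4-cyanophenyl)sulfonyl group gives a 2.1-fold higher number from compound 2 to compound 4 (0.33 log units; beyond the scatter) and is the only one of the two to pass the scatter, if modestly, since the (4-chlorophenyl)sulfonyl group gives a 1.2-fold higher number from compound 2 to compound 3 (0.09 log units; within the scatter) over the same comparison. With the (4-cyanophenyl)sulfonyl group held fixed, pyridin-4-yl in place of pyridin-3-yl gives a 1.0-fold lower number from compound 1 to compound 4 (0.00 log units; within the scatter) and leaves nothing to tell these two pyridine attachments apart in this assay for this pair.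

Nothing available explains these numbers. As far as these compounds go, it remains open how an amine, a methoxy group or a carboxylic acid on that same aromatic carbon would read against chloro and cyano, and whether pyridin-3-yl and pyridin-4-yl would also stay together with the (4-chlorophenyl)sulfonyl group in place.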